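The source may report more compounds than this note shows. Statements on the series, on what has been measured and on what is new or still open speak of the compounds shown alone.

Measured compounds:
Compound 1 `Cc1ccc(C)n1-c1cccc(COc2ccc3c(c2)OCC3CC(=O)O)c1`; in a functional assay on CHO cells for agonist activity at Free fatty acid receptor 1 (Homo sapiens), read by FLIPR and calcium flux (on this read-out lower numbers stand for an effect already at smaller amounts and higher numbers for an effect only at larger amounts of compound), compound 1 gives 53.6 nM.
Compound 2 `Cc1nn(C)c(C)c1-c1cccc(COc2ccc3c(c2)OCC3CC(=O)O)c1`; in this assay compound 2 gives 104 nM.

Among the measured compounds shown here, compound 2 has the highest of the two numbers so far; its nearest neighbour is compound 1, and the step of a 1.9-fold higher number from compound 1 to compound 2 (0.29 log units; within the scatter) lies within the scatter, so the two compounds cannot be ordered on this read-out. Compound 3 `Cc1noc(C)c1-c1cccc(COc2ccc3c(c2)OCC3CC(=O)O)c1` is not yet measured. It differs from compound 2 in one place: 3,5-dimethyl-1,2-oxazol-4-yl in place of 1,3,5-trimethyl-1H-pyrazol-4-yl on an aromatic carbon. The 3,5-dimethyl-1,2-oxazol-4-yl group that enters, like the 1,3,5-trimethyl-1H-pyrazol-4-yl group that leaves, is a five-membered aromatic ring with 2 hetero atoms, 0 hydrogen-bond donors and 2 hydrogen-bond acceptors, and it sits on an aromatic carbon of a six-membered aromatic ring of carbon only, meta to a large group. For the measured compounds named here, only one measured step bears on exchanges of this five-membered ring: a 1.9-fold higher number from compound 1 to compound 2 (0.29 log units; within the scatter), which stayed within the scatter. The account therefore expects no step beyond the scatter in this assay for compound 3, the expected step being a 1.0-fold lower number from compound 2 to compound 3 (0.02 log units; within the scatter). Compound 3 is estimated at 100 nM, with a range from 35 nM to 300 nM.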

Compound 3, half-maximal effective concentration: 27.5 nM
The estimate for compound 3 lay 3.6-fold (0.56 log units) above the measured number, outside the stated range (below it).
By their numbers in this assay, from the lowest: compounds 3, 1 and 2 (each within the scatter of the next, the first and the last beyond it).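

In this assay, among the compounds shown here, the exchange of 1,3,5-trimethyl-1H-pyrazol-4-yl for 3,5-dimethyl-1,2-oxazol-4-yl gives a 3.8-fold lower number from compound 2 to compound 3 (0.58 log units; beyond the scatter) and is the first step on this aromatic carbon to pass the scatter, so this position does tell apart two five-membered aromatic rings that match in hetero atoms, hydrogen-bond donors and hydrogen-bond acceptors. The 2,5-dimethyl-1H-pyrrol-1-yl group of compound 1 does not separate from the new ring, since a 1.9-fold lower number from compound 1 to compound 3 (0.29 log units; within the scatter) leaves these two compounds unordered on this read-out, and only the pyrazole and the oxazole of the three groups stand apart. Nothing measured on these compounds offers an explanation for the step between the pyrazole and the oxazole.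

The compounds shown leave open how much of the step belongs to the ring atoms themselves and how much to the methyl groups the rings carry, which a 1,2-oxazol-4-yl ring without methyl groups, or one with ethyl groups in their place, would address. They also leave open whether a six-membered ring such as a pyridine or a plain phenyl would be accepted on this aromatic carbon as well as the five-membered rings are.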